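This account rests on a few compounds, and the source may have more. Where it says the series, first, only, none or still open, it means among the compounds named here.

Values measured in an ADME assay on S9 fraction from liver (Rattus norvegicus) for metabolic stability, read by LC-MS, using NADPH, with a stated time of 30 min; a lower number here means that less of the compound is left, a higher number that more of the compound is left:

- compound 1 `CCCCCCCCc1ccc(OCC(=O)Cn2nnc(-c3ccc(Cl)cc3)n2)cc1` gives 74%
- compound 2 `CCCCCCCCc1ccc(OCC(=O)Cn2nnc(-c3cccc(Cl)c3)n2)cc1` gives 69%
- compound 3 `CCCCCCCCc1ccc(OCC(=O)Cn2nnc(-c3ccccc3Cl)n2)cc1` gives 28%

Compound 3 has the lowest number of these three. The next structure, compound 4 `CCCCCCCCc1ccc(OCC(=O)Cn2nnc(-c3ccc(S(=O)(=O)N(C)C)cc3)n2)cc1`, differs from it as follows: 4-(dimethylsulfamoyl)phenyl in place of 2-chlorophenyl on an aromatic carbon. In words, 4-(dimethylsulfamoyl)phenyl takes the place of 2-chlorophenyl on an aromatic carbon.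

The useful evidence comes from the three chlorophenyl compounds. The record shows a number 46 percentage points lower from compound 1 to compound 3 (beyond the scatter) and also a number 41 percentage points lower from compound 2 to compound 3 (beyond the scatter), both large, whereas a number 5 percentage points lower from compound 1 to compound 2 (within the scatter) is small. Among these compounds, only the one with 2-chlorophenyl falls low. Compound 4 has no 2-chlorophenyl, and its group carries the 4 label, like the 4-chlorophenyl of compound 1 (74%). For the measured compounds named here, no measured compound has a dimethylsulfamoyl group, so the new group could shift the result either way, and the range must stay wide.

The step expected in this assay is a number 34 percentage points higher from compound 3 to compound 4 (beyond the scatter), a large move upward. Compound 4 is estimated at 62%, with an expected range from 35% to 85%, and the measurement is still to come.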

Compound 4, percent of the compound remaining: 65%
Beside the measured number, compound 4's estimate is 3 percentage points below it, and the stated range covers the measured number.
By their numbers in this assay, from the lowest: compound 3; then compounds 4, 2 and 1 (each within the scatter of the next).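

In this assay, this position on the shared core accepts a far larger replacement than a moved chlorine: the record shows a number 37 percentage points higher from compound 3 to compound 4 (beyond the scatter) when 4-(dimethylsulfamoyl)phenyl replaces 2-chlorophenyl. Against the other two compounds, the new group brings no shift beyond the scatter, with a number 4 percentage points lower from compound 2 to compound 4 (within the scatter) and a number 9 percentage points lower from compound 1 to compound 4 (within the scatter), the latter being a swap of dimethylsulfamoyl for chloro. A chlorine on this phenyl ring is therefore not needed for a high number, and of the four compounds only compound 3 stays low.

Nothing measured here accounts for the low number of the 2-chlorophenyl compound. Still open, on these data alone, is whether a 2-methylphenyl would also fall low, and whether a carboxylic acid or an amine on the phenyl ring would keep the number high.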